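The compounds below may be only part of what the source reports. "The series", "measured", "known", "first", "only" and "open" are said of these compounds alone.

Compound 1 `COc1ccc2nc(C(=O)Nc3ccc(-c4ccccc4)cc3)c(C)c(O)c2c1` gives 3.52% in a functional assay on Hep 3B2 cells (Homo sapiens) for antiproliferative activity, read by MTT assay, with a stated time of 24 h, tested at 0.14 ug/mL; a higher number here means a stronger effect of the compound at the concentration tested, a lower number a weaker effect. Compound 2 `Cc1c(C(=O)Nc2ccc(-c3ccccc3)cc2)nc2ccccc2c1O` gives 3.02% in this assay.

Among these two numbers compound 1 stands highest, with compound 2 nearest, the step of a number 0.5 percentage points lower from compound 1 to compound 2 (within the scatter) lying within the scatter. Both values are small.

Compound 3 `COc1ccc2nc(C(=O)Nc3ccc(-c4ccccc4)cc3)c(C)c(C(=O)O)c2c1` follows from compound 1 by one change: carboxy in place of hydroxy on an aromatic carbon. Going by the values given here, no measured step touches this position; the only step recorded, a number 0.5 percentage points lower from compound 1 to compound 2 (within the scatter), concerns the methoxy group and was within the scatter, so it says nothing direct about the carboxy for hydroxy exchange. With both measured compounds showing only weak inhibition, there is no basis for expecting a step beyond the scatter in this assay in either direction. Compound 3 is therefore estimated at 4%, with a range from 0% to 15%, which amounts to an expected step of a number 0.5 percentage points higher from compound 1 to compound 3 (within the scatter).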

Compound 3, a percentage reported as inhibition, at one concentration (the size of the read-out at that concentration, not a potency): 2.01%
Beside the measured number, compound 3's estimate is 2 percentage points above it; the range from low to high includes it.
By their numbers in this assay, from the lowest: compounds 3, 2 and 1 (each within the scatter of the next).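

Replacing hydroxy with carboxy on the aromatic carbon opposite the ring nitrogen, ortho to a methyl group, gives a number 1.5 percentage points lower from compound 1 to compound 3 (within the scatter) in this assay. Going by these compounds alone, this is the first step recorded at this position, and it shows that adding these heavy atoms there does not move the read-out beyond the scatter, even though the exchange also brings in a double bond outside the aromatic rings. No available evidence accounts for this result.

The compounds shown leave open whether an amine or a methyl ester at this position would give a step beyond the scatter. They also leave open whether a larger effect at this position would appear for any compound built on the shared core, since all the read-outs here are small.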